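Phenoxyacetamide aminothiazoles: halogen swap on the aryl ring

The source may hold more compounds than are shown below. What is called first, only, known or untested is meant among the compounds shown, and "the series" means these compounds.

Measured compounds:
compound 1, `O=C(COc1ccc(Cl)cc1)Nc1nc(-c2ccc(Br)cc2)cs1`, 41400 nM 
compound 2, `O=C(COc1ccc(Cl)cc1)Nc1nc(-c2ccc(Cl)cc2)cs1`, 44100 nM 
compound 3, `Cc1ccc(OCC(=O)Nc2nc(-c3ccc(Br)cc3)cs2)cc1`, 52400 nM 

All three values come from a functional assay on MCF7 cells (Homo sapiens) for cytotoxicity, read by trypan blue exclusion, with a stated time of 48 h; a lower number here means a stronger inhibitor, a higher number a weaker inhibitor. The three numbers lie close together; the steps of a 1.1-fold higher number from compound 1 to compound 2 (0.03 log units; within the scatter) and a 1.3-fold higher number from compound 1 to compound 3 (0.10 log units; within the scatter) are both within the scatter.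

Compound 4, `Cc1ccc(OCC(=O)Nc2nc(-c3ccc(Cl)cc3)cs2)cc1`, is not yet measured. It differs from compound 3 by chloro in place of bromo on an aromatic carbon. The same change has already been measured once, from compound 1 to compound 2: chloro in place of bromo on an aromatic carbon, with the step of a 1.1-fold higher number from compound 1 to compound 2 (0.03 log units; within the scatter). The cores of the two pairs differ by methyl in place of chloro on an aromatic carbon.

Because the earlier step of a 1.1-fold higher number from compound 1 to compound 2 (0.03 log units; within the scatter) is within the scatter, the step from compound 3 to compound 4 is expected to be about as small, a 1.1-fold higher number from compound 3 to compound 4 (0.03 log units; within the scatter). For compound 4 in this assay the estimate is 56000 nM, between 30000 nM and 105000 nM.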

Compound 4, half-maximal inhibitory concentration: 48800 nM
Estimate against measurement, compound 4: 1.1-fold (0.06 log units) above; the measured number falls inside the stated range.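

In this assay, 4-bromophenyl to 4-chlorophenyl on the methyl core gives a 1.1-fold lower number from compound 3 to compound 4 (0.03 log units; within the scatter) and agrees with the step on the chloro core: the same change on two cores in this assay, a 1.1-fold higher number (0.03 log units; within the scatter) from compound 1 to compound 2 and a 1.1-fold lower number (0.03 log units; within the scatter) from compound 3 to compound 4, 1.1-fold (0.06 log units) apart, within the scatter of two such steps.

Methyl in place of chloro, now read on the 4-chlorophenyl core, gives a 1.1-fold higher number from compound 2 to compound 4 (0.04 log units; within the scatter) and likewise agrees with its earlier step: the same change on two cores in this assay, a 1.3-fold higher number (0.10 log units; within the scatter) from compound 1 to compound 3 and a 1.1-fold higher number (0.04 log units; within the scatter) from compound 2 to compound 4, 1.1-fold (0.06 log units) apart, within the scatter of two such steps.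

Both changes therefore carry between these two cores without a readable shift, but every step is within the scatter, so this shows only that they do little here and does not show how either would behave on another core.

The compounds shown leave open whether any other group moves the number beyond the scatter, for instance an amine or a carboxylic acid in place of the chloro, or a longer chain in place of the methyl.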